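The source may hold more compounds than are shown below. What is called first, only, known or untested is meant among the compounds shown, and "the series" means these compounds.

Three compounds from this series have been examined in a functional assay on the whole organism for antagonist activity, with Mus musculus as the target, in the maximal electroshock model; a higher number here means that more compound is needed for the effect, a lower number that less compound is needed. Compound 1 `CCOC(=O)NC1=NC(c2ccccc2Cl)CN1C` gives 28 mg/kg in this assay. Compound 2 `CC(C)OC(=O)NC1=NC(c2ccccc2Cl)CN1C` carries methyl in place of hydrogen on a saturated chain carbon bound to an oxygen next to a carbonyl group and a saturated chain carbon relative to compound 1; in this assay compound 2 gives 35 mg/kg, and the step of a 1.3-fold higher number from compound 1 to compound 2 (0.10 log units; within the scatter) shows that the change from ethoxycarbonyl to isopropoxycarbonyl barely moved the dose. Compound 3 `COC(=O)NC1=NC(c2cccc(Cl)c2)CN1C` is built on a different core, and the difference between the two cores is not broken down here; in this assay compound 3 gives 100 mg/kg, the highest of the three numbers and beyond the scatter from both others.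

Compound 4 `CCOC(=O)NC1=NC(c2cccc(Cl)c2)CN1C` has not yet been measured. It differs from compound 3 by methyl in place of hydrogen on a saturated chain carbon bound to an oxygen next to a carbonyl group, taking methoxycarbonyl to ethoxycarbonyl. This is the same kind of change as that between compound 1 and compound 2, though the place there also bound a saturated chain carbon. Because the step of a 1.3-fold higher number from compound 1 to compound 2 (0.10 log units; within the scatter) lay within the scatter, only a small step of a 1.1-fold lower number from compound 3 to compound 4 (0.05 log units; within the scatter) is expected here too. Compound 4 is therefore estimated at 90 mg/kg in this assay, between 40 mg/kg and 200 mg/kg.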

Compound 4, dose for half-maximal effect: 74 mg/kg
Estimate against measurement, compound 4: 1.2-fold (0.09 log units) above; the range from low to high includes it.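

In this assay, methyl in place of hydrogen on the core of compound 3 gives a 1.4-fold lower number from compound 3 to compound 4 (0.13 log units; within the scatter), so taking methoxycarbonyl to ethoxycarbonyl leaves the dose within the scatter. Set beside the earlier step on the core of compound 1, this step does not differ from it: the same change on two cores in this assay, a 1.3-fold higher number (0.10 log units; within the scatter) from compound 1 to compound 2 and a 1.4-fold lower number (0.13 log units; within the scatter) from compound 3 to compound 4, 1.7-fold (0.23 log units) apart, within the scatter of two such steps. The change can therefore be carried between these two cores without a step beyond the scatter, but this rests on a single pair on each core, and the pairs start from different groups, ethoxycarbonyl on one and methoxycarbonyl on the other, so it does not show that the change would behave alike on any further core.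

The compounds shown leave open whether a longer chain on the oxygen, such as butoxycarbonyl, or a ring there, such as benzyloxycarbonyl, would also leave the dose within the scatter. They also leave open what an amine or a carboxylic acid at the end of that chain would do on either core.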